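The compounds below may be only part of what the source reports. "The series", "measured", "known", "first", "only" and "open" are said of these compounds alone.

Compound 3 `C/C(=C\CC/C(C)=C/CC[C@@H]1[C@@]2(C)CCC(=O)C(C)(C)[C@H]2CC[C@@]1(C)O)CC/C=C(\C)C(=O)OCc1cn(-c2ccccc2C)nn1` stands at the upper edge of what has been measured so far. In an ADME assay on L132 cells (Homo sapiens) for cytotoxicity, read by MTT assay, with a stated time of 48 h (on this read-out higher numbers stand for weaker inhibition and lower numbers for stronger inhibition), compound 3 gives > 150000 nM, which is a limit of the assay rather than a number. Two close relatives frame it. Compound 1 `C/C(=C\CC/C(C)=C/CC[C@@H]1[C@@]2(C)CCC(=O)C(C)(C)[C@H]2CC[C@@]1(C)O)CC/C=C(\C)C(=O)OCc1cn(-c2ccccc2Cl)nn1` also reaches only a limit, giving > 150000 nM in this assay. Compound 2 `C/C(=C\CC/C(C)=C/CC[C@@H]1[C@@]2(C)CCC(=O)C(C)(C)[C@H]2CC[C@@]1(C)O)CC/C=C(\C)C(=O)OCc1cn(-c2cccc(O)c2)nn1` gives 146000 nM in this assay. The steps among these three are small: an at least 1.0-fold lower number from compound 1 to compound 2 (0.01 log units; that floor lies within the scatter), an at least 1.0-fold higher number from compound 2 to compound 3 (0.01 log units; that floor lies within the scatter), and a step that the two limits leave unreadable from compound 1 to compound 3. Two of the three values sit at the limit of > 150000 nM in this assay, at which 2 of the 3 values shown sit, so the compounds are hard to tell apart on this read-out.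

Compound 4 `C/C(=C\CC/C(C)=C/CC[C@@H]1[C@@]2(C)CCC(=O)C(C)(C)[C@H]2CC[C@@]1(C)O)CC/C=C(\C)C(=O)OCc1cn(-c2ccc(C(F)(F)F)cc2)nn1` is the next one to be measured. It differs from compound 3 in one place: 4-(trifluoromethyl)phenyl in place of 2-methylphenyl on an aromatic nitrogen. Among the compounds with values here, none of the measured steps shows a move beyond the scatter, so no step beyond the scatter is expected here either. The expected step is a number no higher from compound 3 to compound 4 (the limit leaves the size open). Compound 4 is therefore expected to give about 150000 nM in this assay, within a range from 100000 nM to 300000 nM, with a fair chance that only a limit is reported once more.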

Compound 4, half-maximal inhibitory concentration: > 150000 nM
Compound 4 was reported as a limit; the forecaster's own chance of this, stated with the estimate: 70%; the middle value lies on the limit itself.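

In this assay compound 4 gives > 150000 nM, which is a limit, even though its 4-(trifluoromethyl)phenyl group has 10 heavy atoms against the 7 of 2-methylphenyl and includes fluorine, unlike the groups in compounds 1, 2 and 3. Within the data shown here, the one readable step is an at least 1.0-fold higher number from compound 2 to compound 4 (0.01 log units; that floor lies within the scatter), while the steps that join two limits cannot be read, so this change on the aromatic nitrogen shows no move beyond the scatter. A fourth group at this position therefore adds one more compound at the same limit: the limit of > 150000 nM in this assay, at which 3 of the 4 values shown sit.

Going by these compounds, it remains open whether an amine or a carboxylic acid on this phenyl ring would give a clearly lower number in this assay. The same is open for a longer chain in place of the ring.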